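A few compounds are considered here, and "the series" means these few. Any claim that something is new, unique, unknown or untested is made for them only; others in the source may bear on it.

Measured so far:
compound 1, `COc1cccc(C(=O)OC(CCN(C)C)c2ccc(Cl)cc2)c1C`: 1950 nM
compound 2, `Cc1ccccc1C(=O)NC(CCN(C)C)c1ccc(Cl)cc1`: 3550 nM

In an assay on NIH3T3 cells with Urotensin-2 receptor (Homo sapiens) as the target (a higher number here means that more compound is needed for the effect, a lower number that less compound is needed), compound 2 holds the highest of the two numbers shown, yet compound 1 at 1950 nM sits within the scatter of it, so no order between the two is claimed. Compound 3 is `Cc1c(Cl)cccc1C(=O)NC(CCN(C)C)c1ccc(Cl)cc1`. It differs from compound 2 by chloro in place of hydrogen on an aromatic carbon. Within the data shown here, no measured pair carries this change, so its size and direction are open; a step beyond the scatter is not required. Compound 3 is expected at 2500 nM, with a range from 800 nM to 8000 nM. The estimated step is a 1.4-fold lower number from compound 2 to compound 3 (0.15 log units; within the scatter).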

Compound 3, half-maximal effective concentration: 1740 nM
Beside the measured number, compound 3's estimate is 1.4-fold (0.16 log units) above it; the range from low to high includes it.
By their numbers in this assay, from the lowest: compounds 3, 1 and 2 (each within the scatter of the next, the first and the last beyond it).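

In this assay, among these compounds, the change from 2-methylphenyl to 3-chloro-2-methylphenyl gives a 2.0-fold lower number from compound 2 to compound 3 (0.31 log units; beyond the scatter) as a modest step, the only single-place comparison so far. It shows that this aromatic carbon, ortho to a methyl group, accepts chloro without loss and that the number responds to a change there. No measurement at hand accounts for the step.

Going by these compounds, whether fluoro, bromo or an amine on the same carbon would shift the number in the same direction remains open. Also open, on these data alone, is whether chloro would give a similar step on the ester compound 1.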